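Swapping 2-bromobenzyl for 3-(trifluoromethyl)benzyl at the limit

The compounds below may be only part of what the source reports. "The series", "measured", "known", "first", "only" and "open" are said of these compounds alone.

Measured in a functional assay on U-251 cells (Homo sapiens) for antiproliferative activity, read by MTT assay, with a stated time of 24 h; on this read-out higher numbers stand for weaker inhibition and lower numbers for stronger inhibition:
- Compound 1 `COc1cc(OC)c(-c2coc3cc(OCc4ccccc4)ccc3c2=O)cc1OC`: 6750 nM
- Compound 2 `COc1cc(OC)c(-c2coc3cc(OCc4ccccc4Cl)ccc3c2=O)cc1OC`: > 10000 nM (a limit, not a number)
- Compound 3 `COc1cc(OC)c(-c2coc3cc(OCc4ccccc4Br)ccc3c2=O)cc1OC`: > 10000 nM (a limit, not a number)

Compound 3 has no exact value on the numbers shown. It sits at the limit of > 10000 nM in this assay, at which 2 of the 3 values shown sit.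

Compound 4 `COc1cc(OC)c(-c2coc3cc(OCc4cccc(C(F)(F)F)c4)ccc3c2=O)cc1OC` has not been measured yet. Its change from compound 3 is 3-(trifluoromethyl)phenyl in place of 2-bromophenyl on a saturated chain carbon bound to an oxygen on an aromatic ring.

Among the measured compounds shown here, no measured step makes this exact swap, so the closest evidence comes from steps that add a group to the same ring. One is an at least 1.4-fold higher number from compound 1 to compound 2 (0.17 log units; that floor lies within the scatter), with chloro in place of hydrogen. The other is an at least 1.4-fold higher number from compound 1 to compound 3 (0.17 log units; that floor lies within the scatter), with bromo in place of hydrogen. Both are only floors, and neither shows a change beyond the scatter. The step that the two limits leave unreadable from compound 2 to compound 3 cannot be read at all.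

With so little to go on, no clear step is expected in this assay, and compound 4 should remain weak. The expected change is a number no higher from compound 3 to compound 4 (the limit leaves the size open). Compound 4 is estimated at about 10000 nM, with an expected range of 4000 nM to 25000 nM.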

Compound 4, half-maximal inhibitory concentration: > 10000 nM
Compound 4 was reported as a limit; the forecaster's own chance of this, stated with the estimate: 55%; the middle value lies on the limit itself.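

In this assay, compound 4 reads > 10000 nM, which is a limit and not a number. The new group, a trifluoromethyl on the benzyl ring, behaves on this evidence like chloro and bromo: an at least 1.4-fold higher number from compound 1 to compound 4 (0.17 log units; that floor lies within the scatter) is only a floor, so this third substituted benzyl also shows no change beyond the scatter from the plain benzyl group. The swap from 2-bromobenzyl to 3-(trifluoromethyl)benzyl, like the other steps among compound 2, compound 3 and compound 4, cannot be read, since both ends of each step are limits, and the result adds only one more compound at the same ceiling: the limit of > 10000 nM in this assay, at which 3 of the 4 values shown sit.

From the compounds shown here alone, only compound 1 has an exact value, so how far compound 2, compound 3 and compound 4 lie past the limit, and whether any group on this ring could lower the number, stays open. How an amine or a carboxylic acid on this ring would read, or a longer chain in place of the benzyl group, is equally unknown from the compounds shown.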